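Carbonyl substituent variation on the piperidine amide

The compounds below may be only part of what the source reports. "The series", "measured", "known", "first", "only" and "open" are said of these compounds alone.

Measured compounds: compound 1 `Cc1nc(S(C)(=O)=O)ccc1Oc1ncnc(OC2CCN(C(=O)O[C@@H](C)CF)CC2)c1F`, 186 nM; compound 2 `Cc1nc(S(C)(=O)=O)ccc1Oc1ncnc(OC2CCN(C(=O)SC(C)(C)C)CC2)c1F`, 4.83 nM; compound 3 `Cc1nc(S(C)(=O)=O)ccc1Oc1ncnc(OC2CCN(C(=O)C3CCCC3)CC2)c1F`, 72.8 nM, all in a functional assay on isolated protein for inhibition of Glucose-dependent insulinotropic receptor (Homo sapiens), read by HTRF and cAMP accumulation; a higher number here means that more compound is needed for the effect, a lower number that less compound is needed.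

Compound 3 stands second highest of the three numbers: nearest is compound 1 with a 2.6-fold lower number from compound 1 to compound 3 (0.41 log units; beyond the scatter), furthest is compound 2 with a 15-fold higher number from compound 2 to compound 3 (1.18 log units; beyond the scatter). Compound 4 `Cc1nc(S(C)(=O)=O)ccc1Oc1ncnc(OC2CCN(C(=O)c3noc(C(C)C)n3)CC2)c1F` carries 5-isopropyl-1,2,4-oxadiazol-3-yl in place of cyclopentyl on a carbonyl carbon. All three measured steps sit on this same carbonyl carbon, and each was beyond the scatter, a 39-fold lower number from compound 1 to compound 2 (1.59 log units; beyond the scatter) being the largest, so this position tolerates large shifts in either direction. Within the data shown here, no measured compound carries a heteroaromatic ring here, so the direction is uncertain; a modest improvement is expected, a 1.8-fold lower number from compound 3 to compound 4 (0.26 log units; within the scatter). Compound 4 is estimated at 40 nM, in the range 8 nM to 200 nM.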

Compound 4, half-maximal effective concentration: 21.2 nM
Estimate against measurement, compound 4: 1.9-fold (0.28 log units) above, and the stated range covers the measured number.
By their numbers in this assay, from the lowest: compound 2; then compound 4; then compound 3; then compound 1.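

In this assay this carbonyl carbon accepts an aromatic ring with hetero atoms: 5-isopropyl-1,2,4-oxadiazol-3-yl improves on cyclopentyl (a 3.4-fold lower number from compound 3 to compound 4 (0.54 log units; beyond the scatter)) and on the group of compound 1 (an 8.8-fold lower number from compound 1 to compound 4 (0.94 log units; beyond the scatter)). The (tert-butyl)sulfanyl group still gives the lowest number of the series (a 4.4-fold higher number from compound 2 to compound 4 (0.64 log units; beyond the scatter)). No available measurement explains these steps.

As far as these compounds go, whether the step comes from the ring or from its isopropyl group stays open. So does the effect of a phenyl or pyridine ring, or of a methyl group in place of isopropyl on the oxadiazole.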